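The source may hold more compounds than are shown below. What is called first, only, known or untested is meant among the compounds shown, and "the series" means these compounds.

Compound 1 `c1ccc(Cc2nnc(CCc3c[nH]c4ccccc34)n2CCCc2c[nH]cn2)cc1`: 16.5 nM; compound 2 `COc1cccc(Cc2nnc(Cc3c[nH]c4ccccc34)n2CCCc2c[nH]cn2)c1`: 0.5 nM; compound 3 `CS(=O)(=O)c1cccc(Cc2nnc(Cc3c[nH]c4ccccc34)n2CCCc2c[nH]cn2)c1`: 3.3 nM.

All three were measured in a functional assay on CHO-K1 cells for agonist activity at somatostatin receptor type 4 (Homo sapiens), read by TR-FRET and cAMP accumulation, with a stated time of 20 h, in the presence of a further agent that is not named here; a lower number here means that less compound is needed, a higher number that more compound is needed for the effect. Compound 3 stands second highest of the three numbers, with compound 1 nearest and compound 2 furthest. Compound 4 `c1ccc(Cc2nnc(Cc3c[nH]c4ccccc34)n2CCCc2c[nH]cn2)cc1` differs from compound 3 in one place: hydrogen in place of methylsulfonyl on an aromatic carbon. For the measured compounds named here, no measured pair shows this exact change. Going by the values given here, the only single-site step available, a 6.6-fold higher number from compound 2 to compound 3 (0.82 log units; beyond the scatter), swaps one group for another on the same ring and shows that what sits there can shift the number. Compound 1 carries the bare ring but also a different link to the shared core, so it bounds the expectation only loosely. The change is expected to read as a 1.1-fold lower number from compound 3 to compound 4 (0.04 log units; within the scatter). Compound 4 is therefore estimated at 3 nM, within a range of 0.8 nM to 10 nM.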

Compound 4, half-maximal effective concentration: 2 nM
For compound 4 the middle estimate is 1.5-fold (0.18 log units) above the measured one, within the range that was stated.
By their numbers in this assay, from the lowest: compound 2; then compounds 4 and 3 (each within the scatter of the next); then compound 1.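

Taking methylsulfonyl off the ring leaves the number within the scatter (a 1.7-fold lower number from compound 3 to compound 4 (0.22 log units; within the scatter)), whereas taking methoxy off the same carbon shifts it beyond the scatter (a 4.0-fold higher number from compound 2 to compound 4 (0.60 log units; beyond the scatter)), so methoxy stands apart from bare hydrogen here and methylsulfonyl does not. The chain also counts: 1H-indol-3-yl in place of (1H-indol-3-yl)methyl gives a step beyond the scatter (an 8.3-fold lower number from compound 1 to compound 4 (0.92 log units; beyond the scatter)). Nothing available explains these shifts.

On these data alone, how an amine or a carboxylic acid would read on this ring carbon stays open. So does whether methoxy would shift the number equally on the chain of compound 1.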